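The compounds below may be only part of what the source reports. "The series", "measured", "known", "first", "only" and "open" are said of these compounds alone.

Measured in an ADME assay on Vero cells (Chlorocebus sabaeus) for cytotoxicity, read by MTT assay, with a stated time of 48 h; a lower number here means a stronger inhibitor, a higher number a weaker inhibitor:
- compound 1 `O=C(OC1CCC(CN2CCN(c3cc(=O)c4cc(C(F)(F)F)cc([N+](=O)[O-])c4s3)CC2)CC1)c1ccccc1`: > 64 ug/mL
- compound 2 `CS(=O)(=O)OC1CCC(CN2CCN(c3cc(=O)c4cc(C(F)(F)F)cc([N+](=O)[O-])c4s3)CC2)CC1`: > 64 ug/mL
- compound 3 `CCCC(=O)OC1CCC(CN2CCN(c3cc(=O)c4cc(C(F)(F)F)cc([N+](=O)[O-])c4s3)CC2)CC1`: > 64 ug/mL

Compound 3 has no number in this assay, only the limit > 64 ug/mL. The same holds across the series, which shows (the limit of > 64 ug/mL in this assay, at which 3 of the 3 values shown sit).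

Compound 4 `O=C(OC1CCC(CN2CCN(c3cc(=O)c4cc(C(F)(F)F)cc([N+](=O)[O-])c4s3)CC2)CC1)C1CCC1` keeps the core of compound 3 and carries cyclobutyl in place of propyl on a carbonyl carbon.

Among the measured compounds shown here, three measured steps bear on this change. The closest is a step that the two limits leave unreadable from compound 1 to compound 3, the only one that also alters the group on a carbonyl carbon. The other two, a step that the two limits leave unreadable from compound 1 to compound 2 and a step that the two limits leave unreadable from compound 2 to compound 3, alter what sits on an oxygen on a saturated carbon. None of the three gives a size, so the series offers no measured effect to carry over. With a step that the two limits leave unreadable from compound 1 to compound 3 unreadable, no step beyond the scatter is expected in either direction, and compound 4 is expected to be reported as a limit again.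

The expected change is a step that the limit leaves unreadable from compound 3 to compound 4, which is an estimate resting on limits alone.

For compound 4 the estimated value is 80 ug/mL, with an expected range from 45 ug/mL to 150 ug/mL.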

Compound 4, half-maximal inhibitory concentration: > 64 ug/mL
Compound 4 was reported as a limit; the forecaster's own chance of this, stated with the estimate: 85%; the middle value does not contradict the limit.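

In this assay, among the compounds shown here, compound 4 gives > 64 ug/mL, a limit and not a number, so no step between compound 4 and compound 1, compound 2 or compound 3 can be read. The series stays where it was: the limit of > 64 ug/mL in this assay, at which 4 of the 4 values shown sit.

The compounds shown leave open what value any of them has in this assay, and whether the group on the carbonyl carbon alters it.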